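The compounds below may be only part of what the source reports. "The series", "measured", "known", "first", "only" and "open" are said of these compounds alone.

Compound 1 `Cc1ccccc1-c1cccc(COc2ccc([C@H](CC(=O)O)c3nccn3C)cc2)c1` gives 89000 nM in an assay on CHO cells for agonist activity at Free fatty acid receptor 1 (Homo sapiens), read by luminescence, with a stated time of 20 s, in the presence of a further agent that is not named here; on this read-out lower numbers stand for an effect already at smaller amounts and higher numbers for an effect only at larger amounts of compound.
Compound 2 `Cc1cc(Cl)ccc1-c1cccc(COc2ccc([C@H](CC(=O)O)c3nccn3C)cc2)c1` gives 10000 nM in this assay.
Compound 3 `Cn1ccnc1[C@@H](CC(=O)O)c1ccc(OCc2cccc(-c3ccccc3Cl)c2)cc1` gives 56000 nM in this assay.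

Compound 3 stands second highest of these three numbers: its gap to compound 1 is within the scatter, while compound 2 sits clearly below it, as the step of a 5.6-fold higher number from compound 2 to compound 3 (0.75 log units; beyond the scatter) shows. Compound 4 `Cc1cc(F)ccc1-c1cccc(COc2ccc([C@H](CC(=O)O)c3nccn3C)cc2)c1` differs from compound 3 by 4-fluoro-2-methylphenyl in place of 2-chlorophenyl on an aromatic carbon. Going by the values given here, two measured steps bear on this change. The step of an 8.9-fold lower number from compound 1 to compound 2 (0.95 log units; beyond the scatter) shows a chloro entering on an aromatic carbon lowering the number beyond the scatter, and the step of a 5.6-fold higher number from compound 2 to compound 3 (0.75 log units; beyond the scatter) shows the reverse direction of the present change, with chloro rather than fluoro. Among the compounds with values here, no compound with a fluoro has been measured. For compound 4 a step of a 2.2-fold lower number from compound 3 to compound 4 (0.35 log units; beyond the scatter) is therefore expected, giving an estimated 25000 nM with a range from 8000 nM to 70000 nM.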

Compound 4, half-maximal effective concentration: 21000 nM
Beside the measured number, compound 4's estimate is 1.2-fold (0.08 log units) above it, and the stated range covers the measured number.
By their numbers in this assay, from the lowest: compound 2; then compound 4; then compounds 3 and 1 (each within the scatter of the next).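

Fluoro in place of hydrogen gives a 4.2-fold lower number from compound 1 to compound 4 (0.63 log units; beyond the scatter) and so also lowers the number, which shows that this effect is not limited to chloro. Chloro still gives the lower number, since fluoro in its place gives a 2.1-fold higher number from compound 2 to compound 4 (0.32 log units; beyond the scatter) as the result. Having 4-fluoro-2-methylphenyl in place of 2-chlorophenyl gives a 2.7-fold lower number from compound 3 to compound 4 (0.43 log units; beyond the scatter) and keeps the order seen with the chloro analogue, but no available evidence explains these differences. Open, from the compounds shown here alone, is whether a methoxy group, a nitrile or an amine, in the place held by the fluoro of 4-fluoro-2-methylphenyl, would lower the number further.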